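The compounds below may be only part of what the source reports. "The series", "measured", "known", "first", "only" and "open" are said of these compounds alone.

Values in an ADME assay on MRC5 cells (Homo sapiens) for cytotoxicity, read by neutral red uptake; on this read-out lower numbers stand for higher toxicity in this test and higher numbers for lower toxicity in this test:

- compound 1 `CSc1nc(-c2cccc(Br)c2)c(C#N)c(=O)[nH]1`: > 64000 nM
- compound 2 `O=c1[nH]c(SCc2cc([N+](=O)[O-])cc([N+](=O)[O-])c2)nc2ccc(Cl)cc12`: > 64000 nM
- compound 3 `O=c1[nH]c(SCc2cc([N+](=O)[O-])cc([N+](=O)[O-])c2)nc2cc(Cl)ccc12`: > 64000 nM

Each of these three entries is a limit of the assay, not a number. The set therefore offers no graded values: all of it stands at the limit of > 64000 nM in this assay, at which 3 of the 3 values shown sit. Compound 2 gives > 64000 nM, which is likewise only a limit. Among the measured compounds shown here, no step between measured compounds can be read from these data, so the size of any single change remains unmeasured.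

Next in line is compound 4 `O=c1[nH]c(SCc2cc([N+](=O)[O-])cc([N+](=O)[O-])c2)nc2ccc(F)cc12`, which departs from compound 2 in one place: fluoro in place of chloro on an aromatic carbon. This is fluoro in place of chloro on an aromatic carbon, with the rest of the structure unchanged.

In this assay, no change beyond the scatter is expected in either direction. The expectation rests on compound 2, whose entry of > 64000 nM is a limit, and on the same limit being shared across the set, as the limit of > 64000 nM in this assay, at which 3 of the 3 values shown sit, shows. The expected a number no higher from compound 2 to compound 4 (the limit leaves the size open) is accordingly small. A further report as a limit is the most likely outcome. The estimated value for compound 4 is 64000 nM, with an expected range from 32000 nM to 128000 nM.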

Compound 4, half-maximal cytotoxic concentration: > 64000 nM
Compound 4: no number, only a limit; the forecaster's own chance of this, stated with the estimate: 85%; the middle value lies on the limit itself.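

In this assay no new step can be read between compound 2 and compound 4, as both entries are limits of the assay and not numbers. The compounds shown leave open at what concentration, if any, toxicity appears in this assay for any of them, and whether fluoro and chloro differ there at all.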